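The source may report more compounds than this note shows. Statements on the series, on what has been measured and on what is new or still open speak of the compounds shown alone.

Among the compounds with values here, compound 3 `CC(C)(C)/[N+]([O-])=C/c1cn(CCC(F)(F)C(F)(F)C(F)(F)C(F)(F)C(F)(F)C(F)(F)F)nn1` sits in a functional assay on PC-3 cells (Homo sapiens) for inhibition, read by MTT assay, with a stated time of 24 h (a higher number here means a weaker inhibitor, a lower number a stronger inhibitor), at 11200 nM, one of only two numbers reported here; compound 2 `[O-]/[N+](=C\c1cn(CCC(F)(F)C(F)(F)C(F)(F)C(F)(F)C(F)(F)C(F)(F)C(F)(F)C(F)(F)F)nn1)Cc1ccccc1` gives 8100 nM, and the gap between them is within the scatter. Compound 1 `[O-]/[N+](=C\c1cn(CCC(F)(F)C(F)(F)C(F)(F)C(F)(F)C(F)(F)C(F)(F)F)nn1)Cc1ccccc1` gives only a limit, > 100000 nM. Compound 4 `CC(C)(C)/[N+]([O-])=C/c1cn(CCC(F)(F)C(F)(F)C(F)(F)C(F)(F)C(F)(F)C(F)(F)C(F)(F)C(F)(F)F)nn1` differs from compound 3 in one place: 1,1,2,2,2-pentafluoroethyl in place of fluoro on a saturated chain carbon bound to two fluorine atoms and a saturated chain carbon. The same change has been measured once before, as an at least 12-fold lower number from compound 1 to compound 2 (1.09 log units; beyond the scatter), a large step. The other measured step, an at least 8.9-fold lower number from compound 1 to compound 3 (0.95 log units; beyond the scatter), starts from the same limit, and the limit of > 100000 nM in this assay, at which 1 of the 3 values shown sits, means both steps are only lower bounds on their true size. A lower number is therefore expected for compound 4, a step of a 5.6-fold lower number from compound 3 to compound 4 (0.75 log units; beyond the scatter). The estimate for compound 4 is 2000 nM, with a range from 500 nM to 8000 nM.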

Compound 4, half-maximal inhibitory concentration: 25700 nM
Estimate against measurement, compound 4: 13-fold (1.11 log units) below; the whole stated range lies below it.
By their numbers in this assay, from the lowest: compounds 2 and 3 (each within the scatter of the next); then compound 4. At a limit, above all of these: compound 1.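

Adding the 1,1,2,2,2-pentafluoroethyl group does not act the same way on every core: with tert-butyl on the double-bonded nitrogen it gives a 2.3-fold higher number from compound 3 to compound 4 (0.36 log units; beyond the scatter), opposite in direction to the change with benzyl there: the same change on two cores in this assay, an at least 12-fold lower number (1.09 log units; beyond the scatter) from compound 1 to compound 2 and a 2.3-fold higher number (0.36 log units; beyond the scatter) from compound 3 to compound 4, at least 28-fold (1.45 log units) apart, beyond the scatter of two such steps

The swap from benzyl to tert-butyl also depends on the chain, now giving a 3.2-fold higher number from compound 2 to compound 4 (0.50 log units; beyond the scatter), so neither change carries over unaltered: the same change on two cores in this assay, an at least 8.9-fold lower number (0.95 log units; beyond the scatter) from compound 1 to compound 3 and a 3.2-fold higher number (0.50 log units; beyond the scatter) from compound 2 to compound 4, at least 28-fold (1.45 log units) apart, beyond the scatter of two such steps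

As far as these compounds go, how a longer fluorinated chain, or a cyclohexyl group on that nitrogen, would behave on either core stays open.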